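This account rests on a few compounds, and the source may have more. Where it says the series, first, only, none or still open, it means among the compounds named here.

The piece follows compound 1, `CS(=O)(=O)c1ccc2c(c1)nc(-c1cccnc1)n2C1CC1`, and the change that leads to compound 3, `Fc1ccc2c(c1)nc(-c1cccnc1)n2C1CC1`. In an assay on V79 cells for inhibition of cytochrome P450 11B1, mitochondrial (Homo sapiens), read by HTRF, with a stated time of 1 h (a lower number here means a stronger inhibitor, a higher number a weaker inhibitor), compound 1 returns only a limit, > 10000 nM. A second compound, compound 2, `CC(C)(C)n1c(-c2cccnc2)nc2ccc(F)cc21`, likewise ends at a limit in this assay, namely > 10000 nM. Both measured results thus sit at the limit of > 10000 nM in this assay, at which 2 of the 2 values shown sit, so compound 1 cannot be ranked against anything shown; it simply gives no number. The change from compound 1 to compound 3 is fluoro in place of methylsulfonyl on an aromatic carbon. Compound 2 already carries that same fluoro and still gives no number, so the fluoro alone is not expected to bring the potency into the measurable range. The expected step from compound 1 to compound 3 is therefore a step that the limit leaves unreadable from compound 1 to compound 3, nothing beyond the scatter. Compound 3 is estimated at 15000 nM, within 5000 nM to 50000 nM, most likely again reported only as a limit.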

Compound 3, half-maximal inhibitory concentration: 3980 nM
For compound 3 the middle estimate is 3.8-fold (0.58 log units) above the measured one, outside the stated range (below it).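

Fluoro in place of methylsulfonyl on this aromatic carbon gives an at least 2.5-fold lower number from compound 1 to compound 3 (0.40 log units; beyond the scatter) in this assay, which shows that the core of compound 1 can reach a measurable potency with a change at this one position. Going by these compounds, compound 1 stands at a limit, > 10000 nM, so this step gives only the smallest size the change can have, and its full size stays unknown. Compound 3 is also the only compound shown that gives a real number rather than a limit: the limit of > 10000 nM in this assay, at which 2 of the 3 values shown sit.

The compounds shown leave open whether fluoro itself helps or whether removing methylsulfonyl is enough. A plain hydrogen, a chlorine or a methoxy group on the same carbon would tell these two readings apart.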